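A few compounds are considered here, and "the series" means these few. Any claim that something is new, unique, unknown or untested is made for them only; others in the source may bear on it.

Of the compounds shown here, three built on one shared core have been measured in an assay on HEK293 cells for positive allosteric modulation of metabotropic glutamate receptor 5 (Homo sapiens), read by FLIPR; on this read-out lower numbers stand for an effect already at smaller amounts and higher numbers for an effect only at larger amounts of compound. Compound 1 `O=C(c1ccc(F)c(F)c1)N1CC(c2nc(-c3cccc(F)c3)no2)C1` gives 3200 nM, compound 2 `O=C(N1CCC(F)CC1)N1CC(c2nc(-c3cccc(Cl)c3)no2)C1` gives 990 nM, and compound 3 `O=C(C1CCC(C(F)(F)F)CC1)N1CC(c2nc(-c3cccc(F)c3)no2)C1` gives 680 nM. Compound 2 thus holds the second highest number of the three: its value lies within the scatter of that of compound 3, while the gap to compound 1 is beyond the scatter. Compound 4 `CC1CCCC(C(=O)N2CC(c3nc(-c4cccc(Cl)c4)no3)C2)C1` awaits measurement. It differs from compound 2 in a single place: 3-methylcyclohexyl in place of 4-fluoropiperidin-1-yl on a carbonyl carbon. For the measured compounds named here, no measured pair shows this exact change, so the expectation rests on compound 2 alone. A modest step toward a lower number, or none beyond the scatter, is expected as a 1.5-fold lower number from compound 2 to compound 4 (0.18 log units; within the scatter). Compound 4 is therefore estimated to give about 650 nM, in the range 200 nM to 2000 nM.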

Compound 4, half-maximal effective concentration: 410 nM
The estimate for compound 4 lay 1.6-fold (0.20 log units) above the measured number; the measured number falls inside the stated range.
By their numbers in this assay, from the lowest: compounds 4, 3 and 2 (each within the scatter of the next, the first and the last beyond it); then compound 1.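

At this place, on a carbonyl carbon whose other neighbours are an amide-type nitrogen in a ring, replacing 4-fluoropiperidin-1-yl with 3-methylcyclohexyl gives in this assay a 2.4-fold lower number from compound 2 to compound 4 (0.38 log units; beyond the scatter). This single change shows that a ring of carbon only, without nitrogen or fluorine, is compatible with a lower number here. No available measurement explains the step.

On these data alone, the change swaps several atoms at once, so which of them matters remains open. A plain cyclohexyl, an unsubstituted piperidin-1-yl or a butyl chain could help separate them.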